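Ring-opened dithiocarbamate amine in the nitroimidazole series

A few compounds are considered here, and "the series" means these few. Any claim that something is new, unique, unknown or untested is made for them only; others in the source may bear on it.

Compound 3 `Cc1ncc([N+](=O)[O-])n1CC(O)CSC(=S)N1CCCC1` gives 1340000 nM in a toxicity assay on HeLa cells (Homo sapiens) for cytotoxicity, read by MTT assay, with a stated time of 24 h; a higher number here means a weaker inhibitor, a lower number a stronger inhibitor. Of the two numbers measured in this assay that is the lowest; compound 2 `Cc1ncc([N+](=O)[O-])n1CC(O)CSC(=S)N1CCN(c2ccccn2)CC1` gives 2970000 nM. Compound 1 `Cc1ncc([N+](=O)[O-])n1CC(O)CSC(=S)N1CCN(c2ccccc2)CC1` reaches only a limit of the assay, > 5000000 nM, and this is what is meant by the limit of > 5000000 nM in this assay, at which 1 of the 3 values shown sits. Going by the values given here, the single step measured between these compounds, an at least 1.6-fold lower number from compound 1 to compound 2 (0.22 log units; that floor lies within the scatter), concerns the amine on the piperazine ring rather than the amine on the thiocarbonyl carbon, and its size offers no firm direction.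

Compound 4 `CCN(CC)C(=S)SCC(O)Cn1c([N+](=O)[O-])cnc1C` differs from compound 3 by diethylamino in place of pyrrolidin-1-yl on a thiocarbonyl carbon. No measured step changes the amine on the thiocarbonyl carbon, and the one step that is measured does not rise above the scatter, so nothing among these compounds speaks for a shift beyond the scatter in either direction. Compound 4 is therefore expected at 1500000 nM, within 500000 nM to 4500000 nM. The expected step of a 1.1-fold higher number from compound 3 to compound 4 (0.05 log units; within the scatter) amounts to no change beyond the scatter.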

Compound 4, half-maximal inhibitory concentration: 2460000 nM
Beside the measured number, compound 4's estimate is 1.6-fold (0.21 log units) below it; the measured number falls inside the stated range.
By their numbers in this assay, from the lowest: compounds 3, 4 and 2 (each within the scatter of the next, the first and the last beyond it). At a limit, above all of these: compound 1.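

Going by these compounds alone, the amine on the thiocarbonyl carbon now has a measured step of its own in this assay, where the only earlier step concerned a different amine: a 1.8-fold higher number from compound 3 to compound 4 (0.26 log units; within the scatter) is the reading for diethylamino in place of pyrrolidin-1-yl. At this position, then, replacing the five-membered ring with an open amine of the same heavy-atom count leaves the number within the scatter, and the ring is not shown to matter for this read-out. Nothing measured here bears on a cause for this step.

Going by these compounds, whether dimethylamino, a longer chain such as dibutylamino, or morpholin-4-yl on a thiocarbonyl carbon would carry the number beyond the scatter stays open. A single step also cannot say whether other open-chain amines at this position would behave in the same way.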